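This account rests on a few compounds, and the source may have more. Where it says the series, first, only, none or still open, it means among the compounds named here.

Compound 2 `Cc1nc(-c2cccc3ccccc23)sc1COc1ccc2c(c1)OCC2CC(=O)O` and compound 1 `Cc1nc(-c2ccc(Cl)s2)sc1COc1ccc2c(c1)OCC2CC(=O)O` share one core and differ only in the aromatic group on the five-membered ring. For the measured compounds named here, in a functional assay on CHO cells for agonist activity at Free fatty acid receptor 1 (Homo sapiens), read by FLIPR and calcium flux, tested at 100 nM (on this read-out lower numbers stand for a weaker effect and higher numbers for a stronger effect at the one concentration tested), compound 1 gives 8.34%, and in this assay compound 2 gives 8.53%; the two values lie within the scatter of each other, so compound 2 stands level with compound 1 on the numbers so far. Going by the values given here, the one step between them, a number 0.2 percentage points higher from compound 1 to compound 2 (within the scatter), is the only measured step at this position. Compound 3 `Cc1ccc(-c2nc(C)c(COc3ccc4c(c3)OCC4CC(=O)O)s2)cc1` carries the change (4-methylphenyl in place of naphthalen-1-yl on an aromatic carbon). Among the compounds with values here, since the only comparable step stayed within the scatter, no movement beyond the scatter is expected here either, and the step of a number 0 percentage points lower from compound 2 to compound 3 (within the scatter) is estimated as essentially flat. Compound 3 is therefore expected to give about 8.5% in this assay, with a range from 1% to 18%.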

Compound 3, a percentage reported as activity, at one concentration (the size of the read-out at that concentration, not a potency): 54.9%
The estimate for compound 3 lay 46.4 percentage points below the measured number; measured number above the stated range.
By their numbers in this assay, from the lowest: compounds 1 and 2 (each within the scatter of the next); then compound 3.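

In this assay, this position is far from flat: 4-methylphenyl in place of naphthalen-1-yl gives a number 46.4 percentage points higher from compound 2 to compound 3 (beyond the scatter), and 4-methylphenyl in place of 5-chlorothiophen-2-yl gives a number 46.6 percentage points higher from compound 1 to compound 3 (beyond the scatter). Of the three groups, only 4-methylphenyl stands apart, which the level pair of compound 1 and compound 2 could not reveal. Nothing shown accounts for this step.

Still open, as far as these compounds go, is whether the methyl group matters, or whether an unsubstituted phenyl or a 4-methoxyphenyl group at this position would give a similar number.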